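Trimethoxyphenyl swap at the low end of the series

This account rests on a few compounds, and the source may have more. Where it says the series, first, only, none or still open, it means among the compounds named here.

- compound 1 `COc1ccc(/C=C/C(=O)/C=C/c2ccc(OCc3cn(CCCCOc4cc(=O)oc5ccccc45)nn3)c(OC)c2)cc1OC`: 55%
- compound 2 `COc1cc(/C=C/C(=O)/C=C/c2cccc3ccccc23)ccc1OCc1cn(CCCCOc2cc(=O)oc3ccccc23)nn1`: 56%
- compound 3 `COc1ccccc1/C=C/C(=O)/C=C/c1ccc(OCc2cn(CCCCOc3cc(=O)oc4ccccc34)nn2)c(OC)c1`: 43%

In a functional assay on HCT-116 cells (Homo sapiens) for inhibition, read by sulforhodamine B assay, with a stated time of 48 h, tested at 50 uM (a lower number here means less inhibition of growth, a higher number more inhibition of growth at the concentration tested), compound 3 stands lowest of the three at 43%, and its gaps to both others lie beyond the scatter. The next compound is compound 4 `COc1cc(/C=C/C(=O)/C=C/c2cc(OC)c(OC)c(OC)c2)ccc1OCc1cn(CCCCOc2cc(=O)oc3ccccc23)nn1`, which differs from compound 3 in one group: 3,4,5-trimethoxyphenyl in place of 2-methoxyphenyl on a double-bonded chain carbon bound to a double-bonded chain carbon. The change is 3,4,5-trimethoxyphenyl in place of 2-methoxyphenyl, on a double-bonded chain carbon bound to a double-bonded chain carbon.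

Two measured steps at that same place bear directly on it: a number 12 percentage points lower from compound 1 to compound 3 (beyond the scatter) and a number 13 percentage points lower from compound 2 to compound 3 (beyond the scatter). Both are modest. The third, a number 1 percentage points higher from compound 1 to compound 2 (within the scatter), stays within the scatter, so compound 3 is the only one of the three set apart. Within the data shown here, no measured compound carries the entering group. Of the groups measured there, the 3,4-dimethoxyphenyl of compound 1 at 55% is the closest match to it, so compound 4 is expected to land near compound 1.

A modest upward move in this assay is therefore expected, and the estimated step is a number 10 percentage points higher from compound 3 to compound 4 (within the scatter). For compound 4 the estimated value is 53%, with an expected range of 41% to 65%.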

Compound 4, percent growth inhibition at one concentration: 63%
Beside the measured number, compound 4's estimate is 10 percentage points below it, within the range that was stated.
By their numbers in this assay, from the lowest: compound 3; then compounds 1, 2 and 4 (each within the scatter of the next).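

In this assay, the 3,4,5-trimethoxyphenyl group on this double-bonded chain carbon gives a number 20 percentage points higher from compound 3 to compound 4 (beyond the scatter) and is the third group that stands apart from the 2-methoxyphenyl of compound 3. Against the other two compounds the picture is flat: the swap from naphthalen-1-yl gives a number 7 percentage points higher from compound 2 to compound 4 (within the scatter) and methoxy in place of hydrogen on an aromatic carbon gives a number 8 percentage points higher from compound 1 to compound 4 (within the scatter) so the 3,4-dimethoxyphenyl, naphthalen-1-yl and 3,4,5-trimethoxyphenyl groups cannot be ordered here, and among the groups shown only 2-methoxyphenyl is set apart. No measurement is at hand that would explain these numbers.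

The compounds shown leave open whether a plain phenyl group at this place would read with compound 3 or with the other three, and how a ring bearing a dimethylamino group or a carboxylic acid would read in this assay. They also leave open whether a longer chain in the linking part of the shared core would shift these numbers; all four compounds carry that part unchanged.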